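A few compounds are considered here, and "the series" means these few. Any claim that something is new, unique, unknown or untested is made for them only; others in the source may bear on it.

Series notes. Compound 1 `CCCCN(CC)c1cc(C)nc2c1NC(=O)CN2c1ccc(Br)cc1Cl` is recorded in an assay on HEK-293T cells for displacement of a labelled ligand from corticotropin-releasing factor receptor 2 (Homo sapiens), read by scintillation counting, with a stated time of 2 h, tested at 1 uM (on this read-out lower numbers stand for less inhibition and higher numbers for more inhibition at the one concentration tested (going by the name of the read-out)), only as "not determined" (no result reported); compound 2 `CCCCN(CC)c1cc(C)nc2c1NC(=O)CN2c1ccc(Cl)cc1C` is a further entry recorded there as "not determined" (no result reported). Among the measured compounds shown here, the one measured entry is compound 3 `CCCCN(CC)c1cc(C)nc2c1NC(=O)CN2c1ccc(C)cc1Br`, which in this assay gives 5.5%. Compound 4 `CCCCN(CC)c1cc(C)nc2c1NC(=O)CN2c1ccc(C)cc1C` is still to be tested in this assay. From compound 1 to compound 4 the change is 2,4-dimethylphenyl in place of 4-bromo-2-chlorophenyl on a nitrogen on an aromatic ring in a ring. For the measured compounds named here, with compound 1 unmeasured, no step to compound 4 can be read from data; in this assay that step is expected to stay within the scatter, in no particular direction, since the only number in the set is small. Resting on compound 3 at 5.5%, compound 4 is expected to give about 6%, between -8% and 25%.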

Compound 4, a percentage reported as inhibition, at one concentration (the size of the read-out at that concentration, not a potency): 6.8%
Estimate against measurement, compound 4: 0.8 percentage points below; the measured number falls inside the stated range.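

In this assay, methyl in place of bromo on an aromatic carbon gives a number 1.3 percentage points higher from compound 3 to compound 4 (within the scatter), so this exchange on the phenyl ring does not separate the two compounds. Steps involving compound 1 or compound 2 cannot be read. No supporting measurement bears on this result.

As far as these compounds go, it remains open whether an amine or a carboxylic acid at this place on the phenyl ring would move the inhibition beyond the scatter. From the compounds shown here alone, it is also open whether a change elsewhere on the shared core would do so.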